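This account rests on a few compounds, and the source may have more. Where it says the series, first, only, none or still open, it means among the compounds named here.

Compound 1 `COc1ccc(OC)c(/C=N/NC(=O)Nc2ccc(Oc3ccnc(-c4nncn4CCN(C)C)c3)c(F)c2)c1` gives 6400 nM in a functional assay on U-87MG ATCC cells (Homo sapiens) for cytotoxicity, read by MTT assay, with a stated time of 72 h; on this read-out lower numbers stand for stronger inhibition and higher numbers for weaker inhibition.
Compound 2 `CN(C)CCn1cnnc1-c1cc(Oc2ccc(NC(=O)N/N=C/c3cccc(Br)c3)cc2F)ccn1` gives 830 nM in this assay.
Compound 3 `CN(C)CCn1cnnc1-c1cc(Oc2ccc(NC(=O)N/N=C/c3cccc(O)c3)cc2F)ccn1` reaches only a limit of the assay in this assay, > 100000 nM, so no number is known for it.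

Compound 3 therefore stands at the weak end of what has been measured, sitting at the limit of > 100000 nM in this assay, at which 1 of the 3 values shown sits, rather than at a number. Compound 4 `CN(C)CCn1cnnc1-c1cc(Oc2ccc(NC(=O)N/N=C/c3ccc(F)cc3Cl)cc2F)ccn1` differs from compound 3 in one place: 2-chloro-4-fluorophenyl in place of 3-hydroxyphenyl on a carbon with a double bond to nitrogen. Among the compounds with values here, two measured steps bear on this change. The step of an at least 120-fold higher number from compound 2 to compound 3 (2.08 log units; beyond the scatter) shows that putting a hydroxy group onto the aromatic ring in place of a bromo atom pushed the number past the limit, and the step of an at least 15-fold higher number from compound 1 to compound 3 (1.19 log units; beyond the scatter) shows the same direction when the 2,5-dimethoxyphenyl of compound 1 was exchanged for the 3-hydroxyphenyl. Compound 4 moves the other way, from the hydroxy-bearing ring back to a ring carrying only halogens, so a large drop in the number, beyond the scatter, is expected in this assay, toward the range occupied by compound 1 and compound 2. Compound 4 is therefore estimated at 1500 nM, with a range from 400 nM to 8000 nM, an expected step of an at least 66-fold lower number from compound 3 to compound 4 (1.82 log units; beyond the scatter).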

Compound 4, half-maximal inhibitory concentration: 1210 nM
Compound 4: the middle estimate sits 1.2-fold (0.09 log units) above what was measured; low and high end bracket the measured number.
By their numbers in this assay, from the lowest: compounds 2 and 4 (each within the scatter of the next); then compound 1. At a limit, above all of these: compound 3.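

On the carbon with a double bond to nitrogen, 2-chloro-4-fluorophenyl in place of 3-hydroxyphenyl brings a ring with two halogens and no hydroxy group, and in this assay this returns a measurable number (an at least 82-fold lower number from compound 3 to compound 4 (1.91 log units; beyond the scatter)). A second halogen-bearing ring thus lands with the first, as the exchange of 3-bromophenyl for 2-chloro-4-fluorophenyl gives only a small difference (a 1.5-fold higher number from compound 2 to compound 4 (0.16 log units; within the scatter)), while both halogen-bearing rings give lower numbers than the 2,5-dimethoxyphenyl ring, here with 2-chloro-4-fluorophenyl (a 5.3-fold lower number from compound 1 to compound 4 (0.72 log units; beyond the scatter)). The large step out of compound 3 has only a lower bound and no exact size, since compound 3 is a limit of the assay and not a number: the limit of > 100000 nM in this assay, at which 1 of the 4 values shown sits.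

The compounds shown leave open how a plain phenyl ring, or a ring carrying an amine or a carboxylic acid, would behave on this carbon. They also do not separate the contribution of the chloro from that of the fluoro within the 2-chloro-4-fluorophenyl ring.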